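A few compounds are considered here, and "the series" means these few. Any claim that something is new, unique, unknown or untested is made for them only; others in the source may bear on it.

In a functional assay on SW-620 cells (Homo sapiens) for inhibition, read by MTT assay, with a stated time of 72 h (a higher number here means a weaker inhibitor, a lower number a stronger inhibitor), compound 1 `COc1cc(NC(C)CCCNC(=O)Nc2cccc(F)c2)c2ncccc2c1` gives 27000 nM and compound 2 `COc1cc(NC(C)CCCNC(=O)Nc2cccc(Cl)c2)c2ncccc2c1` gives 26000 nM. Chloro in place of fluoro on an aromatic carbon amounts to a 1.0-fold lower number from compound 1 to compound 2 (0.02 log units; within the scatter), so compound 2 stands level with compound 1. Compound 3 `COc1cc(NC(C)CCCNC(=O)NNC(=O)Nc2ccc(F)cc2)c2ncccc2c1` reads > 100000 nM, which is a limit of the assay and not a number. The steps to it, an at least 3.7-fold higher number from compound 1 to compound 3 (0.56 log units; beyond the scatter) and an at least 3.8-fold higher number from compound 2 to compound 3 (0.58 log units; beyond the scatter), put ((4-fluorophenyl)carbamoyl)amino on the amide-type nitrogen, a larger exchange than the one considered next, and they bear on it only loosely.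

Compound 4 `COc1cc(NC(C)CCCNC(=O)Nc2ccc(F)cc2)c2ncccc2c1` has not yet been measured. It differs from compound 2 by 4-fluorophenyl in place of 3-chlorophenyl on an amide-type nitrogen, with 4-fluorophenyl in place of 3-chlorophenyl on an amide-type nitrogen. The nearest guide is the exchange between compound 1 and compound 2, a 1.0-fold lower number from compound 1 to compound 2 (0.02 log units; within the scatter), so no shift beyond the scatter is expected in this assay. The expected step is a 1.1-fold higher number from compound 2 to compound 4 (0.03 log units; within the scatter). Compound 4 is estimated at 28000 nM, with an expected range of 12000 nM to 65000 nM.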

Compound 4, half-maximal inhibitory concentration: 25000 nM
The estimate for compound 4 lay 1.1-fold (0.05 log units) above the measured number, within the range that was stated.
By their numbers in this assay, from the lowest: compounds 4, 2 and 1 (each within the scatter of the next). At a limit, above all of these: compound 3.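

In this assay, the earlier pair exchanged only chloro for fluoro, whereas a 1.1-fold lower number from compound 1 to compound 4 (0.03 log units; within the scatter) exchanges 3-fluorophenyl for 4-fluorophenyl and a 1.0-fold lower number from compound 2 to compound 4 (0.02 log units; within the scatter) exchanges 3-chlorophenyl for 4-fluorophenyl, so on this amide-type nitrogen neither a change of halogen nor a change in the halogen's place shifts the number beyond the scatter. For the compounds shown here, the only step here beyond the scatter is an at least 4.0-fold lower number from compound 3 to compound 4 (0.60 log units; beyond the scatter), and it now compares two compounds that both carry a 4-fluorophenyl group. Compound 3 stands at a limit and not a number, so that step gives only a bound: the limit of > 100000 nM in this assay, at which 1 of the 4 values shown sits.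

From the compounds shown here alone, whether an amine or a carboxylic acid in place of the halogen on the phenyl group would move the number beyond the scatter stays open. So does the outcome of a longer chain in place of the one that links the urea to the shared core.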